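The source may report more compounds than this note shows. Statements on the series, on what has been measured and on what is new or still open speak of the compounds shown alone.

Measured in a functional assay on MDA-MB-231 cells (Homo sapiens) for inhibition, read by MTT assay, with a stated time of 48 h; on this read-out lower numbers stand for stronger inhibition and higher numbers for weaker inhibition:
compound 1, `COc1cc(-c2cc(/C=C/C(=O)c3ccc(N)cc3)[nH]n2)cc(OC)c1OC`, gives 2000 nM;
compound 2, `COc1cc(-c2cc(/C=C/C(=O)c3ccc(Cl)c(Cl)c3)[nH]n2)cc(OC)c1OC`, gives 2100 nM;
compound 3, `COc1ccc(C(=O)/C=C/c2cc(-c3cc(OC)c(OC)c(OC)c3)n[nH]2)cc1OC`, gives 620 nM.

Compound 1 stands second highest of the three numbers, with compound 2 within the scatter of it and compound 3 the furthest away. Compound 4, `COc1ccc(C(=O)/C=C/c2cc(-c3cc(OC)c(OC)c(OC)c3)n[nH]2)cc1`, differs from compound 1 by methoxy in place of amino on an aromatic carbon. Two measured steps on the same carbonyl-bound ring bear on this: a 1.1-fold higher number from compound 1 to compound 2 (0.02 log units; within the scatter), and a 3.2-fold lower number from compound 1 to compound 3 (0.51 log units; beyond the scatter). The change to compound 4 shares with compound 3 a methoxy entering where the amino was, but lacks the further methoxy present in compound 3. A modest lowering is therefore expected, smaller than that seen with compound 3, estimated as a 1.7-fold lower number from compound 1 to compound 4 (0.22 log units; within the scatter). For compound 4 the number expected in this assay is 1200 nM, with a range from 500 nM to 2800 nM.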

Compound 4, half-maximal inhibitory concentration: 950 nM
Compound 4: middle estimate off by 1.3-fold (0.10 log units), on the high side; low and high end bracket the measured number.
By their numbers in this assay, from the lowest: compounds 3 and 4 (each within the scatter of the next); then compounds 1 and 2 (each within the scatter of the next).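

In this assay, one methoxy on the carbonyl-bound ring is enough to carry the number beyond the scatter, against the amino of compound 1 (a 2.1-fold lower number from compound 1 to compound 4 (0.32 log units; beyond the scatter)) and against the two chlorines of compound 2 (a 2.2-fold lower number from compound 2 to compound 4 (0.34 log units; beyond the scatter)). The further methoxy of compound 3 adds nothing that can be told apart (a 1.5-fold higher number from compound 3 to compound 4 (0.19 log units; within the scatter)), so the step seen with compound 3 is already reached with the 4-methoxyphenyl alone. No measurement at hand accounts for these steps.

Open, as far as these compounds go, is whether a hydroxyl or an ethoxy in the same place would hold the number of compound 4.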